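A few compounds are considered here, and "the series" means these few. Any claim that something is new, unique, unknown or untested is made for them only; others in the source may bear on it.

Compound 1 `O=C(CCCCCn1cc(Nc2ncc3ccn(Cc4ccccc4)c3n2)cn1)NO` gives 13.8 nM in an assay on isolated protein for inhibition of protein deacetylase HDAC6 (Homo sapiens), with a stated time of 60 min (a higher number here means a weaker inhibitor, a lower number a stronger inhibitor), the highest of the three numbers measured, although compound 2 `O=C(CCCCCCn1cc(Nc2ncc3ccn(Cc4ccccc4)c3n2)cn1)NO` with 12.5 nM and compound 3 `O=C(CCCCCCn1cc(Nc2ncc3ccn(Cc4ccccc4F)c3n2)cn1)NO` with 8.4 nM both sit within the scatter of it. The change that leads to compound 4 `O=C(CCCCCn1cc(Nc2ncc3ccn(Cc4ccccc4Cl)c3n2)cn1)NO` is chloro in place of hydrogen on an aromatic carbon. Among the measured compounds shown here, no measured step makes this exact change. The closest is the step of a 1.5-fold lower number from compound 2 to compound 3 (0.17 log units; within the scatter), which likewise brings a halogen onto the benzyl ring, and the step of a 1.1-fold lower number from compound 1 to compound 2 (0.04 log units; within the scatter) on the chain likewise stayed within the scatter. A step in this assay no larger than the scatter is therefore expected, and compound 4 is estimated at 11 nM, between 5 nM and 25 nM, which amounts to an expected step of a 1.3-fold lower number from compound 1 to compound 4 (0.10 log units; within the scatter).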

Compound 4, half-maximal inhibitory concentration: 45 nM
The estimate for compound 4 lay 4.1-fold (0.61 log units) below the measured number; measured number outside the range, above it.
By their numbers in this assay, from the lowest: compounds 3, 2 and 1 (each within the scatter of the next); then compound 4.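

Chloro in place of hydrogen on the benzyl ring, ortho to a large group, is the first change among these compounds to move the number beyond the scatter, with a 3.3-fold higher number from compound 1 to compound 4 (0.51 log units; beyond the scatter). The ring carbon therefore does not accept every halogen without consequence, whereas the fluoro change, on the longer chain, stayed within the scatter with a 1.5-fold lower number from compound 2 to compound 3 (0.17 log units; within the scatter). Nothing available explains this weaker inhibition.

Going by these compounds, it remains open whether 2-chlorobenzyl would cost as much on the longer chain of compound 2. On these data alone, the effect of a methyl or methoxy group on this ring carbon also remains open.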